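Compound 3: methoxy in place of (2,4-dichlorobenzyl)amino

A few compounds are considered here, and "the series" means these few. Any claim that something is new, unique, unknown or untested is made for them only; others in the source may bear on it.

In a functional assay on MDA-MB-435 cells (Homo sapiens) for cytotoxicity, read by MTT assay, with a stated time of 72 h (a higher number here means a weaker inhibitor, a lower number a stronger inhibitor), compound 1 `COc1cccc(CNC(=O)c2nc(Br)c3cccnc3c2N[C@H]2CC[C@H](N)CC2)c1` gives 7000 nM and compound 2 `N[C@H]1CC[C@H](Nc2c(C(=O)NCc3ccc(Cl)cc3Cl)nc(Br)c3cccnc23)CC1` gives 5800 nM, so these two numbers lie within the scatter of each other. Compound 3 `COC(=O)c1nc(Br)c2cccnc2c1N[C@H]1CC[C@H](N)CC1` differs from compound 2 by methoxy in place of (2,4-dichlorobenzyl)amino on a carbonyl carbon. Among the compounds with values here, only one measured step bears on this change, and only loosely. That step, a 1.2-fold lower number from compound 1 to compound 2 (0.08 log units; within the scatter), swaps one substituted phenyl for another and keeps the amide-type nitrogen, whereas compound 3 loses both that nitrogen and the aromatic ring. Within the data shown here, no measured compound shows what such a loss does, so any forecast is uncertain. A modest move toward a higher number, meaning a weaker inhibitor, is the tentative expectation. The estimated change in this assay is a 2.1-fold higher number from compound 2 to compound 3 (0.32 log units; beyond the scatter). For compound 3 the expected value is 12000 nM, within an estimated range of 3000 nM to 40000 nM.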

Compound 3, half-maximal inhibitory concentration: > 20000 nM
Compound 3: a limit, no number; the forecaster's own chance of this, stated with the estimate: 15%; middle value at least 1.6-fold (0.22 log units) away from the limit.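

Compound 3 gives a limit of the assay, not a number: the limit of > 20000 nM in this assay, at which 1 of the 3 values shown sits.

Even read as a limit, the change of the amide to the methoxy ester on this carbonyl carbon registers clearly in this assay, with an at least 3.4-fold higher number from compound 2 to compound 3 (0.53 log units; beyond the scatter) and an at least 2.8-fold higher number from compound 1 to compound 3 (0.45 log units; beyond the scatter). The earlier step, a 1.2-fold lower number from compound 1 to compound 2 (0.08 log units; within the scatter), swapped only one substituted phenyl for another, whereas these steps show that removing the aromatic ring and the amide-type nitrogen together does move the number beyond the scatter.

Both leave together in compound 3, so the compounds shown do not tell whether the ring or the nitrogen accounts for the difference. A primary amide, which keeps that nitrogen without the ring, or a benzyl ester, which keeps the ring without the nitrogen, would separate the two.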